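The compounds below may be only part of what the source reports. "The series", "measured", "known", "first", "only" and "open" are said of these compounds alone.

- compound 1 `COc1cc(/C=C2\CN(C)C/C(=C\c3ccc(F)cc3)C2=O)cc(OC)c1`: 5040 nM
- compound 2 `COc1cc(/C=C2\CN(C)C/C(=C\c3ccc(Cl)c(Cl)c3)C2=O)cc(OC)c1`: 3260 nM

These values come from a functional assay on THP-1 cells (Homo sapiens) for cytotoxicity, read by MTT assay, with a stated time of 24 h; on this read-out lower numbers stand for stronger inhibition and higher numbers for weaker inhibition. Going by the values given here, only two compounds have been measured, and their numbers lie within the scatter of each other, so compound 1 has no distinct rank between them.

The next compound is compound 3 `COc1cc(/C=C2\CN(C)C/C(=C\c3ccc(F)cc3)C2=O)cc(OC)c1OC`, which keeps the 4-fluorophenyl of compound 1 and changes the other aromatic ring: methoxy in place of hydrogen on an aromatic carbon. A methoxy replaces a hydrogen on an aromatic carbon, ortho to two methoxy groups and para to a large group.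

Among the compounds with values here, the only measured step is a 1.5-fold lower number from compound 1 to compound 2 (0.19 log units; within the scatter). It swaps 4-fluorophenyl for 3,4-dichlorophenyl, so it shows a change at a different place, and it stays within the scatter. Within the data shown here, no measured step touches the carbon that changes here, which leaves the direction open. The data therefore give no reason to expect a shift beyond the scatter in this assay.

The expected change is small, a 1.3-fold lower number from compound 1 to compound 3 (0.12 log units; within the scatter). The estimate for compound 3 is 3800 nM, with an expected range from 1300 nM to 10000 nM.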

Compound 3, half-maximal inhibitory concentration: 6130 nM
Compound 3: middle estimate off by 1.6-fold (0.21 log units), on the low side, within the range that was stated.
By their numbers in this assay, from the lowest: compounds 2, 1 and 3 (each within the scatter of the next).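

Placing a methoxy on the aromatic carbon ortho to two methoxy groups and para to a large group gives, in this assay, a 1.2-fold higher number from compound 1 to compound 3 (0.09 log units; within the scatter), so the two numbers cannot be told apart. Going by these compounds alone, this is the first measured look at this aromatic ring, since the earlier step changed only the 4-fluorophenyl on the other side of the molecule, and it shows that this hydrogen can be replaced by a group of 2 heavy atoms, including 1 hydrogen-bond acceptor, with no shift that stands out from the usual scatter of repeated measurements. No measured information on the compounds explains why the number stays within that scatter.

Going by these compounds, one hydrogen-to-methoxy swap says little about this carbon in general, so it remains open whether an amine, a carboxylic acid or a longer chain such as butoxy at the same place would move the number beyond the scatter. On these data alone, it also remains open whether the same methoxy would give a similarly small step when the 4-fluorophenyl is replaced by the 3,4-dichlorophenyl of compound 2.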